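From (butylamino)methyl to piperidin-1-yl

The source may report more compounds than this note shows. Statements on the series, on what has been measured and on what is new or still open speak of the compounds shown alone.

- compound 1 `CC(C)NCCC(=O)Nc1cccc2c1CN(C)CC2c1ccccc1` gives 150 mg/kg as its value
- compound 2 `CCCCNCCC(=O)Nc1cccc2c1CN(C)CC2c1ccccc1` gives about 46 mg/kg as its value

In a functional assay on the whole organism for inhibition, with Mus musculus as the target (on this read-out lower numbers stand for an effect already at smaller amounts and higher numbers for an effect only at larger amounts of compound), compound 2 holds the lower of the two numbers, at about 46 mg/kg in this small set. Compound 3 `CN1Cc2c(NC(=O)CN3CCCCC3)cccc2C(c2ccccc2)C1` is not yet measured and departs from compound 2 in one place, on a saturated chain carbon bound to a carbonyl carbon, where the difference is piperidin-1-yl in place of (butylamino)methyl on a saturated chain carbon bound to a carbonyl carbon and nothing else changes. Within the data shown here, only one measured step bears on this. It is a 3.3-fold lower number from compound 1 to compound 2 (0.51 log units; beyond the scatter) with butyl in place of isopropyl on an amine nitrogen, modest in size and beyond the scatter. Read in reverse, it suggests that losing the butyl leads to a higher number, though no measured compound carries a ring there. The estimated change is a 2.2-fold higher number from compound 2 to compound 3 (0.34 log units; beyond the scatter) and is expected to be similarly modest, toward a higher number. For compound 3 the expected value is 100 mg/kg with an estimated range from 30 mg/kg to 300 mg/kg overall.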

Compound 3, dose for half-maximal effect: about 65 mg/kg
Beside the measured number, compound 3's estimate is 1.5-fold (0.19 log units) above it, within the range that was stated.
By their numbers in this assay, from the lowest: compounds 2 and 3 (each within the scatter of the next); then compound 1.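

In this assay the move from an open chain to a ring at this place, on a saturated chain carbon bound to a carbonyl carbon, reads as a 1.4-fold higher number from compound 2 to compound 3 (0.15 log units; within the scatter) and so leaves piperidin-1-yl and (butylamino)methyl indistinguishable, even though the ring has 0 hydrogen-bond donors against 1 for the chain. The same ring, set against the smaller branched group, gives a 2.3-fold lower number from compound 1 to compound 3 (0.36 log units; beyond the scatter) and therefore stands apart from (isopropylamino)methyl as the butyl chain does, so among these three compounds an amine hydrogen at this place is not needed to reach the lower numbers. Nothing available explains these numbers.

The compounds shown leave open how a pyrrolidin-1-yl or morpholin-4-yl ring would read at this place. They also leave open whether a chain longer than butyl on the amine nitrogen would change the number.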